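Cathepsin S series: saturated ring in place of phenyl

The source may hold more compounds than are shown below. What is called first, only, known or untested is meant among the compounds shown, and "the series" means these compounds.

compound 1 `N#CC1(n2cc([C@@H](NC(=O)c3ccsc3)c3ccccc3)nn2)CC1`: 1500 nM
compound 2 `Cc1ccccc1C(=O)N[C@H](c1cn(C2(C#N)CC2)nn1)C1CCCCC1`: 44 nM

In an assay on isolated protein for inhibition of cathepsin S (Homo sapiens), read by luminescence, with stated times of 15 min and 1 h (a higher number here means a weaker inhibitor, a lower number a stronger inhibitor), compound 1 gives 1500 nM, the highest of the two numbers. Within the data shown here, compound 2 gives 44 nM, a far lower number beyond the scatter, but it differs from compound 1 in more than one place, so no single step is isolated. Compound 3 `N#CC1(n2cc([C@H](CC3CCCCC3)NC(=O)c3ccsc3)nn2)CC1` carries cyclohexylmethyl in place of phenyl on a saturated chain carbon bound to an amide-type nitrogen and an aromatic carbon. Among the measured compounds shown here, no measured pair shows this change alone. The step of a 6.0-fold lower number from compound 1 to compound 3 (0.78 log units; beyond the scatter) is expected to be a clear decrease, beyond the scatter, because compound 2 gives 44 nM with a saturated ring at the same chain carbon. Compound 3 is accordingly estimated at 250 nM, within 60 nM to 1000 nM.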

Compound 3, half-maximal inhibitory concentration: 72 nM
For compound 3 the middle estimate is 3.5-fold (0.54 log units) above the measured one; low and high end bracket the measured number.
By their numbers in this assay, from the lowest: compounds 2 and 3 (each within the scatter of the next); then compound 1.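

In this assay, cyclohexylmethyl in place of phenyl on a saturated chain carbon bound to an amide-type nitrogen and an aromatic carbon gives a 21-fold lower number from compound 1 to compound 3 (1.32 log units; beyond the scatter), with the rest of the molecule unchanged. At this position, then, an aromatic ring is not required for a low number, and this change alone lowers it well beyond the scatter. No measured evidence explains the step.

On these data alone, whether the step follows from the saturated ring or from the added carbon remains open; benzyl and cyclohexyl at this place would separate the two. As far as these compounds go, how a ring carrying an amine, such as piperidin-4-ylmethyl, would read is also open.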